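Oxidising the butylsulfanyl group of compound 2: an expectation

This account rests on a few compounds, and the source may have more. Where it says the series, first, only, none or still open, it means among the compounds named here.

Of the compounds shown here, two have been measured in a functional assay (spleen, spleen) for activation, with Mus musculus as the target; a lower number here means that less compound is needed, a higher number that more compound is needed for the effect. Compound 1 `Nc1ncnc2c1nc(Cl)n2Cc1ccccc1` reaches only the limit of the assay, > 10 uM, so no number is known for it; this is the limit recorded as the limit of > 10 uM in this assay, at which 1 of the 2 values shown sits. Going by the values given here, compound 2 `CCCCSc1nc(N)c2nc(O)n(Cc3ccccc3)c2n1` gives 0.01 uM in this assay, the only real number of the two. Compounds 1 and 2 differ in more than one place, so nothing is drawn from the gap between them.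

Compound 3 `CCCC[S+]([O-])c1nc(N)c2nc(O)n(Cc3ccccc3)c2n1` carries one change relative to compound 2: a group of 6 heavy atoms (4 carbon, 1 oxygen, 1 sulfur; no ring) in place of a group of 5 heavy atoms (4 carbon, 1 sulfur; no ring), on an aromatic carbon. Among the compounds with values here, no measured pair of compounds shows this change, so the size of the step is open. A modest loss is expected. Compound 3 is estimated to give 0.05 uM in this assay, within a range from 0.01 uM to 0.3 uM. The expected step from compound 2 to compound 3 is a 5.0-fold higher number from compound 2 to compound 3 (0.70 log units; beyond the scatter), a little beyond the usual scatter.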

Compound 3, minimum effective concentration: 0.01 uM
Compound 3: the middle estimate sits 5.0-fold (0.70 log units) above what was measured; the range from low to high includes it.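

Placing an oxygen on the sulfur of the butylsulfanyl group gives no change at the digits printed from compound 2 to compound 3 (within the scatter) in this assay. Going by these compounds alone, this is the first single-change comparison, and it shows that this aromatic carbon, between two ring nitrogen atoms, can carry the larger oxygen-bearing group with no measurable loss in this read-out. Nothing in the data explains why the added oxygen leaves the result unchanged.

This single step cannot show whether the same would hold for other groups at this carbon, such as a sulfone, an amine or a longer chain. It also leaves open whether the outcome would be the same with other changes elsewhere on the shared core, as only one position has been compared directly.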